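Amide to urea on the shared core: expected cell toxicity

The compounds below may be only part of what the source reports. "The series", "measured", "known", "first", "only" and "open" are said of these compounds alone.

Compound 1 `COc1cc(-c2nn(-c3cccc(NC(=O)c4ccc(Cl)c(C(F)(F)F)c4)c3)cc2-c2ccncc2)ccc1Cl` is known in a functional assay on MOLT-4 cells (Homo sapiens) for inhibition, read by sulforhodamine B assay, with a stated time of 48 h (on this read-out higher numbers stand for lower toxicity in this test and lower numbers for higher toxicity in this test), only through a limit: compound 1 gives > 32500 nM, a limit of the assay and not a number. The evidence on compound 1 in this assay is therefore (the limit of > 32500 nM in this assay, at which 1 of the 2 values shown sits), and compound 1 cannot be placed on a scale against any number. Compound 2 `O=C(Nc1cccc(-n2cc(-c3ccncc3)c(-c3ccc(Cl)c(O)c3)n2)c1)Nc1cc(C(F)(F)F)cc(C(F)(F)F)c1` likewise gives only a limit in this assay, > 50000 nM. Compound 3 `COc1cc(-c2nn(-c3cccc(NC(=O)Nc4cccc(C(F)(F)F)c4)c3)cc2-c2ccncc2)ccc1Cl` is not yet measured in this assay. It differs from compound 1 in one place: (3-(trifluoromethyl)phenyl)amino in place of 4-chloro-3-(trifluoromethyl)phenyl on a carbonyl carbon. Going by the values given here, no step between measured compounds is available to size this change, and both values shown are limits. The expectation for compound 3 is no step beyond the scatter, most probably another limit. Compound 3 is estimated at 40000 nM, within 15000 nM to 100000 nM. The expected step is a step that the limit leaves unreadable from compound 1 to compound 3.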

Compound 3, concentration lethal to 50% of the cells: > 50000 nM
Compound 3: only a limit was reported; the forecaster's own chance of this, stated with the estimate: 75%; middle value at least 1.2-fold (0.09 log units) away from the limit.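

In this assay compound 1 gives > 32500 nM, a limit and not a number. Compound 3 gives > 50000 nM, also a limit, so no step can be read between compound 1 and compound 3. Left open is whether (3-(trifluoromethyl)phenyl)amino in place of 4-chloro-3-(trifluoromethyl)phenyl changes this read-out at all.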